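Amino in Place of Methyl on a Receptor Agonist

The source may report more compounds than this note shows. Statements on the series, on what has been measured and on what is new or still open speak of the compounds shown alone.

Two compounds that share a core were tested in a functional assay on HEK293 cells for agonist activity at G-protein coupled receptor 84 (Homo sapiens), read by calcium flux; a higher number here means that more compound is needed for the effect, a lower number that less compound is needed. Compound 1 `CC(C)CCCc1nc(O)cc(O)n1` gives 2110 nM there. Compound 2 `Cc1cc(O)nc(SCCCCc2ccccc2)n1` is a different case: for compound 2 this assay reports only a limit, > 100000 nM, which is the limit of > 100000 nM in this assay, at which 1 of the 2 values shown sits. Compound 2 therefore stands at the edge of what the assay can report, with no number to place it against compound 1.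

Compound 3 `Nc1cc(O)nc(SCCCCc2ccccc2)n1` has not yet been measured in this assay. Its difference from compound 2 is amino in place of methyl on an aromatic carbon. Going by the values given here, no step between measured compounds shows how such a change moves the read-out, so the expected direction rests on the change alone. The step from compound 2 to compound 3 is expected to be an at least 3.3-fold lower number from compound 2 to compound 3 (0.52 log units; beyond the scatter), toward less compound needed, though a limit remains quite possible. Compound 3 is estimated at 30000 nM, within a range from 3000 nM to 150000 nM.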

Compound 3, half-maximal effective concentration: > 100000 nM
Compound 3: only a limit was reported; the forecaster's own chance of this, stated with the estimate: 45%; at least 3.3-fold (0.52 log units) between middle value and limit.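

Compound 2 and compound 3 both stand at a limit in this assay and no step can be read between them, so the two results give no size for this change: the limit of > 100000 nM in this assay, at which 2 of the 3 values shown sit.

Going by these compounds, whether amino in place of methyl on an aromatic carbon moves the read-out at all, and in which direction, stays open.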